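A few compounds are considered here, and "the series" means these few. Any claim that something is new, unique, unknown or untested is made for them only; others in the source may bear on it.

Measured compounds in the series:

- compound 1 `COc1ccc(F)cc1CNCCCNc1ccnc2cc(Cc3cccc(C(F)(F)F)c3)ccc12`: 4200 nM
- compound 2 `COc1ccc(F)cc1CNCCCNc1ccnc2cc(-c3cccc4ccccc34)ccc12`: 32000 nM

For the measured compounds named here, in a physicochemical assay for solubility, with a stated time of 18 h, at pH 7.4 (on this read-out higher numbers stand for higher solubility and lower numbers for lower solubility), compound 2 stands at the top of the two numbers so far, with compound 1 the nearer neighbour at a lower value; the step of a 7.6-fold higher number from compound 1 to compound 2 (0.88 log units; beyond the scatter) is the only one recorded at this position of the shared core. Compound 3 `COc1ccc(F)cc1CNCCCNc1ccnc2cc(Oc3ccccc3OC)ccc12` carries the change (2-methoxyphenoxy in place of naphthalen-1-yl on an aromatic carbon). Going by the values given here, the one measured step bears on it only indirectly, since it exchanged different groups at the same aromatic carbon; it does show that this position moves this assay by a modest amount. The entering group is smaller and brings two acceptors where the leaving group had none, so for compound 3 a further modest rise in this assay is expected, a 1.9-fold higher number from compound 2 to compound 3 (0.27 log units; within the scatter). The estimate for compound 3 is 60000 nM, with a range from 20000 nM to 180000 nM.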

Compound 3, solubility: 14500 nM
Compound 3: middle estimate off by 4.1-fold (0.62 log units), on the high side, outside the stated range (below it).
By their numbers in this assay, from the lowest: compound 1; then compound 3; then compound 2.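

In this assay, all three groups on this aromatic carbon now separate beyond the scatter, with 2-methoxyphenoxy ranked by two steps: a 2.2-fold lower number from compound 2 to compound 3 (0.34 log units; beyond the scatter) and a 3.5-fold higher number from compound 1 to compound 3 (0.54 log units; beyond the scatter). Naphthalen-1-yl, with 0 hydrogen-bond acceptors, keeps the higher number against 2-methoxyphenoxy, with 2, so in this pair the acceptor count does not follow the read-out. No measurement at hand accounts for this order.

The compounds shown do not separate the part played by the ether oxygen from that of the methoxy group within 2-methoxyphenoxy, and plain phenoxy would be the direct comparison. Also open, going by these compounds, is how an amine such as piperazine or a carboxylic acid on the same aromatic carbon would stand against these three groups.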